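The source may hold more compounds than are shown below. What is called first, only, known or untested is meant among the compounds shown, and "the series" means these compounds.

Compound 1 `CCCCCNC(=O)CC1CCc2cc(OC)c(OC)cc21` gives 37.7% in a functional assay on the whole organism (strain Wistar) for inhibition, with Rattus norvegicus as the target, read by paw edema, with stated times of 60 min and 3 h, at a dose of 100 mg/kg by the oral route; on this read-out higher numbers stand for more inhibition at the one dose given (going by the name of the read-out) and lower numbers for less inhibition.
Compound 2 `COc1cc2c(cc1OC)C(CC(=O)NC1CCCCC1)CC2` gives 49.3% in this assay.

In this assay compound 2 stands highest of the two numbers, with compound 1 the nearer one, since a number 11.6 percentage points higher from compound 1 to compound 2 (beyond the scatter). Compound 3 `COc1cc2c(cc1OC)C(CC(=O)N1CCCC1)CC2` differs from compound 2 by pyrrolidin-1-yl in place of cyclohexylamino on a carbonyl carbon. Going by the values given here, the single measured step, a number 11.6 percentage points higher from compound 1 to compound 2 (beyond the scatter), concerns an exchange of groups on an amide-type nitrogen and so does not bear directly on this change. With no guide, no change beyond the scatter is expected, a number 5.3 percentage points lower from compound 2 to compound 3 (within the scatter). Compound 3 is therefore estimated at 44%, within 28% to 60%.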

Compound 3, a percentage reported as inhibition, in the whole organism at one dose (the size of the read-out at that dose, not a potency): 26.1%
Beside the measured number, compound 3's estimate is 17.9 percentage points above it, and the stated range ends above it.
By their numbers in this assay, from the lowest: compound 3; then compound 1; then compound 2.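

In this assay the change on the carbonyl carbon matters in both comparisons: pyrrolidin-1-yl gives a number 23.2 percentage points lower from compound 2 to compound 3 (beyond the scatter), and against the open chain it gives a number 11.6 percentage points lower from compound 1 to compound 3 (beyond the scatter). Compound 3 is the only one of the three without a hydrogen-bond donor in this group, and it stands lowest. No measurement here explains this drop.

The compounds shown leave open whether the lower number goes with the lost amide hydrogen or with the five-membered ring. A cyclopentylamino group or a piperidin-1-yl group would help to separate the two.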